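A few compounds are considered here, and "the series" means these few. Any claim that something is new, unique, unknown or untested is made for them only; others in the source may bear on it.

Going by the values given here, in a functional assay on A549 cells (Homo sapiens) for antiproliferative activity, read by MTT assay, with a stated time of 72 h (a higher number here means a weaker inhibitor, a lower number a stronger inhibitor), compound 1 `COc1cc(-c2nc(N(C)C)sc2-c2ccc3ccccc3c2)cc(OC)c1OC` gives 2900 nM, the only true number available. Compound 2 `CCOc1ccc(-c2sc(N(C)C)nc2-c2cc(OC)c(OC)c(OC)c2)cc1` reads > 10000 nM, which is a limit of the assay and not a number. Its standing is therefore known only as the limit of > 10000 nM in this assay, at which 1 of the 2 values shown sits. Among the compounds with values here, the one measured step is an at least 3.4-fold higher number from compound 1 to compound 2 (0.53 log units; beyond the scatter), beyond the scatter, and it places 4-ethoxyphenyl where naphthalen-2-yl stood on an aromatic carbon. Within the data shown here, that step concerns a different group, so it bears only indirectly on what follows, and no measured step covers the next change. Compound 3 `CCOc1ccc(-c2sc(C)nc2-c2cc(OC)c(OC)c(OC)c2)cc1` keeps the 4-ethoxyphenyl group of compound 2 but carries methyl in place of dimethylamino on an aromatic carbon, next to the ring nitrogen and next to the ring sulfur (methyl in place of dimethylamino on an aromatic carbon). With compound 1 at 2900 nM as the only numerical anchor, a modest move to a lower number in this assay is expected. Compound 3 may also stay at the limit. The expected change is an at least 2.5-fold lower number from compound 2 to compound 3 (0.39 log units; beyond the scatter). For compound 3 the estimate is 4000 nM, with an expected range from 300 nM to 10000 nM.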

Compound 3, half-maximal inhibitory concentration: 3320 nM
Compound 3: the middle estimate sits 1.2-fold (0.08 log units) above what was measured; the measured number falls inside the stated range.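

With the 4-ethoxyphenyl group held fixed, placing methyl in place of dimethylamino on an aromatic carbon, next to the ring nitrogen and next to the ring sulfur, gives an at least 3.0-fold lower number from compound 2 to compound 3 (0.47 log units; beyond the scatter) in this assay. Going by these compounds alone, the earlier compounds showed only a change at the ring atom that bears the large aryl group, so this is the first sign that the read-out also responds to the group at this carbon, with 1 heavy atom entering where 3 leave. The full size of this step cannot be stated because compound 2 stands at a limit of the assay and not at a number: the limit of > 10000 nM in this assay, at which 1 of the 3 values shown sits.

One pair cannot tell whether the shift belongs to methyl itself or to the loss of dimethylamino, and an ethyl group, a primary amine or a lone hydrogen on the same carbon would be needed to separate the two. On these data alone, it also remains open whether methyl would act in the same way alongside the naphthalen-2-yl group of compound 1.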